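The compounds below may be only part of what the source reports. "The series", "measured", "known", "first", "only" and "open" are said of these compounds alone.

Compound 1, `CN(C)c1cccc(C(=O)N[C@H]2CCC[C@H](NC(=O)c3cccc(Cl)c3)C2)c1`: in a functional assay on HEK293 cells for antagonist activity at metabotropic glutamate receptor 5 (Homo sapiens), read by FLIPR and calcium flux (a higher number here means a weaker inhibitor, a lower number a stronger inhibitor), compound 1 gives > 10000 nM, which is a limit of the assay.
Compound 2, `O=C(N[C@H]1CCC[C@H](NC(=O)c2ccccn2)C1)c1cccc(Cl)c1`: in this assay compound 2 gives > 10000 nM, also a limit of the assay.
Compound 3, `O=C(N[C@H]1CCC[C@H](NC(=O)c2cccc(Cl)c2)C1)c1ccncc1`: in this assay compound 3 gives 300 nM.

Among these three, compound 3 is the only one with a number; the other two sit at the limit of > 10000 nM in this assay, at which 2 of the 3 values shown sit. Compound 4, `O=C(N[C@H]1CCC[C@H](NC(=O)c2ccccc2F)C1)c1cccc(Cl)c1`, has not yet been measured in this assay. It differs from compound 3 in one place: 2-fluorophenyl in place of pyridin-4-yl on a carbonyl carbon. Among the measured compounds shown here, two measured steps bear on this change, since both end at the pyridin-4-yl of compound 3: an at least 33-fold lower number from compound 1 to compound 3 (1.52 log units; beyond the scatter) and an at least 33-fold lower number from compound 2 to compound 3 (1.52 log units; beyond the scatter). The step that the two limits leave unreadable from compound 1 to compound 2 adds nothing readable. For the measured compounds named here, both readable steps show that arriving at pyridin-4-yl brings a large fall in the number, so its removal is expected to push the number back up, and 2-fluorophenyl itself appears in no measured compound. The author therefore expects for compound 4 a large rise, a 13-fold higher number from compound 3 to compound 4 (1.12 log units; beyond the scatter), with a real chance that only a limit is reported. The estimate for compound 4 in this assay is 4000 nM, ranging from 600 nM to 10000 nM.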

Compound 4, half-maximal inhibitory concentration: 175 nM
For compound 4 the middle estimate is 23-fold (1.36 log units) above the measured one, outside the stated range (below it).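

In this assay, 2-fluorophenyl in place of pyridin-4-yl on this carbonyl carbon gives a 1.7-fold lower number from compound 3 to compound 4 (0.23 log units; within the scatter), even though the entering group is a ring of carbon only with no hydrogen-bond acceptor. Across this pair, then, the ring nitrogen of pyridin-4-yl is not required for a measurable number, which the earlier compounds could not show, as pyridin-4-yl was then the only group at this position with one. The same group also gives an at least 57-fold lower number from compound 2 to compound 4 (1.75 log units; beyond the scatter) and an at least 57-fold lower number from compound 1 to compound 4 (1.75 log units; beyond the scatter), so the position separates these groups sharply, and neither a ring nitrogen nor its absence sorts them, with pyridin-2-yl in compound 2 and 3-(dimethylamino)phenyl in compound 1 going against any such rule.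

Compound 1 and compound 2 each stand at a limit of the assay, so how far they really lie from the other two stays open: the limit of > 10000 nM in this assay, at which 2 of the 4 values shown sit. The compounds shown also leave open what the fluorine itself contributes, which a plain phenyl would test, and how this position would respond to a saturated amine such as piperidine or to a carboxylic acid.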